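From chloro to hydroxy on compound 2

A few compounds are considered here, and "the series" means these few. Any claim that something is new, unique, unknown or untested is made for them only; others in the source may bear on it.

In a functional assay on A549 cells (Homo sapiens) for inhibition, read by MTT assay (on this read-out lower numbers stand for stronger inhibition and higher numbers for weaker inhibition), compound 1 `N#Cc1cccc(-c2cn(CCCCCCn3cccc(/C=C/C(=O)NO)c3=O)nn2)c1` gives 600 nM while compound 2 `O=C(CCC(=O)Nc1nnc(-c2ccc(Cl)cc2)s1)NO` gives 14700 nM and so holds the higher of the two numbers, meaning the weaker inhibition, with a gap beyond the scatter. Compound 3 `O=C(CCC(=O)Nc1nnc(-c2ccc(O)cc2)s1)NO` has not been measured yet. The change hydroxy in place of chloro on an aromatic carbon turns the 4-chlorophenyl of compound 2 into 4-hydroxyphenyl, with hydroxy in place of chloro on an aromatic carbon. Among the measured compounds shown here, no measured pair shows this swap, so the estimated step of a 1.2-fold higher number from compound 2 to compound 3 (0.09 log units; within the scatter) in this assay is expected to stay within the scatter, slightly upward if anything. For compound 3 the expected value is 18000 nM with a range from 6000 nM to 50000 nM in this estimate.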

Compound 3, half-maximal inhibitory concentration: 14700 nM
Estimate against measurement, compound 3: 1.2-fold (0.09 log units) above; the measured number falls inside the stated range.
By their numbers in this assay, from the lowest: compound 1; then compounds 2 and 3 (each within the scatter of the next).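

In this assay, among the compounds shown here, hydroxy in place of chloro on the aromatic carbon para to a large group gives no change at the digits printed from compound 2 to compound 3 (within the scatter) in the first pair to test this position. Here, a hydrogen-bond donor and acceptor enter with hydroxy, and the number stays within the scatter. No measurement shown gives a reason for this result. Going by these compounds, whether an amine, a carboxylic acid or a methoxy group at this position would also stay within the scatter remains open. One pair also cannot say whether this swap would read the same on another core.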